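Isopropyl Gives Way to Propyl: A Small Step Expected

This account rests on a few compounds, and the source may have more. Where it says the series, first, only, none or still open, it means among the compounds named here.

Of the compounds shown here, two sharing one core have so far been tested in a functional assay on A549 cells (Homo sapiens) for antiproliferative activity, read by CCK-8 assay, with a stated time of 72 h; on this read-out lower numbers stand for stronger inhibition and higher numbers for weaker inhibition. Compound 1 (`Nc1ccccc1NC(=O)c1ccc(COc2ccc(Cl)cc2)cc1`) reports only a limit, > 32000 nM. Within the data shown here, compound 2 (`CC(C)c1ccc(OCc2ccc(C(=O)Nc3ccccc3N)cc2)cc1`) gives 7460 nM, the only actual number so far. Among the measured compounds shown here, the single measured step is an at least 4.2-fold lower number from compound 1 to compound 2 (0.63 log units; beyond the scatter), with isopropyl in place of chloro on an aromatic carbon, and one end of it rests on a limit (the limit of > 32000 nM in this assay, at which 1 of the 2 values shown sits).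

Compound 3 (`CCCc1ccc(OCc2ccc(C(=O)Nc3ccccc3N)cc2)cc1`) differs from compound 2 in one place: propyl in place of isopropyl on an aromatic carbon. The change sits para to a large group, and the two compounds have the same atoms, joined differently. The step to compound 2, an at least 4.2-fold lower number from compound 1 to compound 2 (0.63 log units; beyond the scatter), shows that a change at this place can move the number, but it compares no two carbon chains. A change within the scatter or only slightly beyond it is therefore expected, with no firm direction. The expected step is a 1.1-fold lower number from compound 2 to compound 3 (0.06 log units; within the scatter). Compound 3 is estimated at 6500 nM in this assay, with an expected range of 3000 nM to 15000 nM.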

Compound 3, half-maximal inhibitory concentration: 5210 nM
For compound 3 the middle estimate is 1.2-fold (0.10 log units) above the measured one; measured number inside the range.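

In this assay, exchanging isopropyl for propyl, the same atoms joined differently at this position, gives a 1.4-fold lower number from compound 2 to compound 3 (0.16 log units; within the scatter), so this first comparison of two carbon chains here does not separate them. The step from chloro now has a second example, an at least 6.1-fold lower number from compound 1 to compound 3 (0.78 log units; beyond the scatter), and so both carbon chains shown stand beyond the scatter against the chloro compound, with only a lower bound on the size of each step. For compound 1, the end of both steps is a limit and not a number: the limit of > 32000 nM in this assay, at which 1 of the 3 values shown sits.

The compounds shown leave open whether a shorter chain such as methyl, or a longer chain such as butyl or pentyl, would move the number beyond the scatter of compound 2 and compound 3. They also leave open how an amine or a carboxylic acid would read at the same place, and whether a hydrogen there would read closer to the carbon chains or to chloro.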